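Methyl to Fluoro on an Aromatic Carbon: What to Expect

The source may report more compounds than this note shows. Statements on the series, on what has been measured and on what is new or still open speak of the compounds shown alone.

Measured compounds:
Compound 1, `COc1cc(OC)c(OC)cc1/C=C/C(=O)c1ccc(C)cc1`, gives 2.24 ug/mL in a functional assay on cells (Erythrocyte, Rattus norvegicus) for inhibition, read by hemolysis, with a stated time of 1 h; a higher number here means a weaker inhibitor, a lower number a stronger inhibitor.
Compound 2, `COc1cc(OC)c(OC)cc1/C=C/C(=O)c1ccc(Cl)c([N+](=O)[O-])c1`, gives 2.15 ug/mL in this assay.
Compound 3, `COc1cc(OC)c(-c2cc(=O)c3ccc(O)cc3o2)cc1OC`, gives 2.15 ug/mL in this assay.

Of the compounds shown here, three have been tested so far, and their numbers sit close together. Compound 1 has the highest of the three numbers, but its gap to compound 2 and to compound 3 lies within the scatter of repeated measurements, so the three cannot be ranked against one another on this evidence.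

Compound 4, `COc1cc(OC)c(OC)cc1/C=C/C(=O)c1ccc(F)cc1`, has not been measured yet. It differs from compound 1 in one place: fluoro in place of methyl on an aromatic carbon. Nothing else in the structure moves.

For the measured compounds named here, no pair of measured compounds differs in a single place, so there is no measured step of this kind to lean on. Given how tightly the three known numbers cluster in this assay, the expectation for the change from methyl to fluoro is a step no larger than the scatter, in no firm direction. Compound 4 is therefore expected to give about 2.3 ug/mL, within a range of 1.1 ug/mL to 4.6 ug/mL, which corresponds to an expected step of a 1.0-fold higher number from compound 1 to compound 4 (0.01 log units; within the scatter).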

Compound 4, half-maximal inhibitory concentration: 2.22 ug/mL
Estimate against measurement, compound 4: 1.0-fold (0.02 log units) above; the range from low to high includes it.
By their numbers in this assay, from the lowest: compounds 2, 3, 4 and 1 (each within the scatter of the next).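

In this assay, for the compounds shown here, fluoro in place of methyl gives a 1.0-fold lower number from compound 1 to compound 4 (0.00 log units; within the scatter), the only measured step here between two compounds that differ in one place, and the two compounds cannot be told apart. Going by these compounds alone, for this one pair, then, the 4-methylphenyl and 4-fluorophenyl versions of the shared core read alike at this position, on an aromatic carbon para to a large group, which the earlier compounds could only suggest through their loose clustering and never test directly. No measurement shown here accounts for why the two groups read alike, so no explanation can be offered.

Open, on these data alone, is whether this position stays just as undemanding for groups of a different kind, such as an amine, a carboxylic acid or a longer chain, since methyl and fluoro are both single heavy atoms without hydrogen-bond donors or acceptors and so sample only a narrow slice of what could sit there. Also open, as far as these compounds go, is whether the same swap would read alike on another core, as a single pair on a single core cannot show how far the result carries.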